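Benzofuran amide series: replacing the cyclopropyl linker

The source may report more compounds than this note shows. Statements on the series, on what has been measured and on what is new or still open speak of the compounds shown alone.

Measured so far:
compound 1, `CCC(=O)NC[C@@H]1CC1c1cccc2oc(CCCCc3ccccc3)cc12`, 2.1 nM
compound 2, `CC(C)C(=O)NC[C@@H]1CC1c1cccc2oc(CCCCc3ccccc3)cc12`, 23 nM

In an assay on NIH3T3 cells for binding affinity to melatonin receptor type 1A (Homo sapiens) (a lower number here means a stronger inhibitor, a higher number a weaker inhibitor), compound 1 gives 2.1 nM, the lowest of the two numbers; the nearest is compound 2 with 23 nM. Among the compounds with values here, the only measured step, an 11-fold higher number from compound 1 to compound 2 (1.04 log units; beyond the scatter), changes the acyl part while leaving the linker untouched, so it shows that this assay responds strongly to alterations around the amide.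

Compound 3, `CC(=O)NCCCc1cccc2oc(CCCCc3ccccc3)cc12`, is not yet measured. Compared with compound 1 the change is 3-acetamidopropyl in place of 2-((propanoylamino)methyl)cyclopropyl on an aromatic carbon. Within the data shown here, no measured step covers this change: the acyl group shortens and the three-membered ring leaves at the same time, and neither alteration has been tested on its own. Given how large the step from compound 1 to compound 2 was, a modest loss is expected rather than none, with wide uncertainty: compound 3 is estimated at 10 nM (range 2 nM to 60 nM), meaning an expected step of a 4.8-fold higher number from compound 1 to compound 3 (0.68 log units; beyond the scatter).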

Compound 3, inhibition constant: 19 nM
Beside the measured number, compound 3's estimate is 1.9-fold (0.28 log units) below it; measured number inside the range.
By their numbers in this assay, from the lowest: compound 1; then compounds 3 and 2 (each within the scatter of the next).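

On this aromatic carbon, 3-acetamidopropyl in place of 2-((propanoylamino)methyl)cyclopropyl gives a 9.0-fold higher number from compound 1 to compound 3 (0.96 log units; beyond the scatter) in this assay, so the change costs affinity beyond the scatter. Even so, the open chain, with no ring and no defined stereocentre, keeps a nanomolar number: compound 3 gives 19 nM in this assay, which shows that the three-membered ring is not needed for binding in the nanomolar range. No separate evidence bears on the origin of this step.

From the compounds shown here alone, the step combines two alterations, a shorter acyl group and the loss of the ring, so how much of it belongs to each stays open. A 3-(propanoylamino)propyl chain on the same aromatic carbon would separate the two, while a longer chain such as 4-acetamidobutyl would test the length of the linker.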